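The compounds below may be only part of what the source reports. "The series", "measured", "known", "first", "only" and "open" are said of these compounds alone.

Measured in a functional assay on RAW264.7 cells (Mus musculus) for inhibition, read by polymerase chain reaction, with stated times of 12 h and 6 h; on this read-out lower numbers stand for stronger inhibition and higher numbers for weaker inhibition:
- compound 1 `Cc1ccc(C)c(OCCCC(C)(C)C(=O)NC2CCN(Cc3ccc(Cl)cc3)CC2)c1`: 14800 nM
- compound 2 `Cc1ccc(CN2CCC(NC(=O)C(C)(C)Oc3ccc(C(=O)c4ccc(Cl)cc4)cc3)CC2)cc1`: 8560 nM
- compound 3 `CC(C)(Oc1ccc(C(=O)c2ccc(Cl)cc2)cc1)C(=O)NC1CCN(Cc2ccc(OC(F)(F)F)cc2)CC1`: 9760 nM

In this assay, compound 1 lies within the scatter of both compound 2 and compound 3, so the three values are not separated. Compound 4 `Cc1ccc(C)c(OCCCC(C)(C)C(=O)NC2CCN(Cc3ccc(F)cc3)CC2)c1` has fluoro in place of chloro on an aromatic carbon, para to a large group: fluoro in place of chloro on an aromatic carbon. No chloro to fluoro swap has been measured. The nearest evidence is a different substituent exchange, trifluoromethoxy in place of methyl on an aromatic carbon, which gave a 1.1-fold higher number from compound 2 to compound 3 (0.06 log units; within the scatter). No change beyond the scatter is therefore expected. The expected result is a 1.1-fold lower number from compound 1 to compound 4 (0.02 log units; within the scatter). Compound 4 is estimated at 14000 nM, with an expected range of 7000 nM to 28000 nM.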

Compound 4, half-maximal inhibitory concentration: 4560 nM
For compound 4 the middle estimate is 3.1-fold (0.49 log units) above the measured one; the measured number lies below the stated range.
By their numbers in this assay, from the lowest: compounds 4, 2, 3 and 1 (each within the scatter of the next, the first and the last beyond it).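

Among the compounds shown here, exchanging 4-chlorobenzyl for 4-fluorobenzyl gives the first step in this assay that clears the scatter (a 3.2-fold lower number from compound 1 to compound 4 (0.51 log units; beyond the scatter)), so the group at this position can change the read-out on the core of compound 1. For the compounds shown here, the only earlier exchange at this kind of position stayed within the scatter on a different core (a 1.1-fold higher number from compound 2 to compound 3 (0.06 log units; within the scatter)). No measurement at hand accounts for the step.

Going by these compounds, whether the same exchange lowers the number on the core of compound 2 remains open. So does the effect of a nitrile or an amine on the same aromatic carbon.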